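Fluoro-to-methyl swap on the fused ring of compound 2

The source may report more compounds than this note shows. Statements on the series, on what has been measured and on what is new or still open speak of the compounds shown alone.

Among the compounds with values here, in a functional assay on HT-29 cells (Homo sapiens) for inhibition, read by MTT assay, with a stated time of 72 h (a lower number here means a stronger inhibitor, a higher number a weaker inhibitor), compound 2 `CN(C)CCn1c(=O)c(=Cc2ccc(F)c(F)c2)s/c1=C1\C(=O)Nc2ccc(F)cc21` gives 3090 nM, the higher of the two numbers measured so far. Compound 1 `Cc1ccc2c(c1)/C(=c1/sc(=Cc3ccc(C=O)c(C=O)c3)c(=O)n1CCN(C)C)C(=O)N2` gives 1030 nM in this assay, the lower number, and the gap between the two lies beyond the scatter. Compound 3 `Cc1ccc2c(c1)/C(=c1/sc(=Cc3ccc(F)c(F)c3)c(=O)n1CCN(C)C)C(=O)N2` is not yet measured; it differs from compound 2 by methyl in place of fluoro on an aromatic carbon. Within the data shown here, no measured pair isolates this change. Compound 3 is expected to show at most a small step in this assay, a 1.5-fold lower number from compound 2 to compound 3 (0.19 log units; within the scatter), toward a lower number, likely within the scatter. Compound 3 is estimated at 2000 nM, with a range of 800 nM to 5000 nM.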

Compound 3, half-maximal inhibitory concentration: 7430 nM
For compound 3 the middle estimate is 3.7-fold (0.57 log units) below the measured one, and the stated range ends below it.
By their numbers in this assay, from the lowest: compound 1; then compound 2; then compound 3.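

In this assay, methyl in place of fluoro on this aromatic carbon is not a silent exchange: a 2.4-fold higher number from compound 2 to compound 3 (0.38 log units; beyond the scatter), a step beyond the scatter for a swap of one heavy atom. With methyl kept there, 3,4-difluorophenyl in place of 3,4-diformylphenyl gives a 7.2-fold higher number from compound 1 to compound 3 (0.86 log units; beyond the scatter), so the double-bonded chain substituent also shifts the number. Nothing at hand gives a reason for either step. From the compounds shown here alone, it remains open where an amine or a methoxy group on this aromatic carbon would fall relative to fluoro and methyl. Going by these compounds, whether the fluoro-to-methyl step holds alongside 3,4-diformylphenyl also remains open.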